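A few compounds are considered here, and "the series" means these few. Any claim that something is new, unique, unknown or untested is made for them only; others in the source may bear on it.

The two compounds measured so far in a functional assay on BXPC-3 cells (Homo sapiens) for cytotoxicity, read by MTT assay, with a stated time of 72 h (on this read-out higher numbers stand for weaker inhibition and lower numbers for stronger inhibition), are:

compound 1, `CCc1ccc(-c2ccc(NC3=CC(=O)c4ncncc4C3=O)cc2)cc1`: 3100 nM
compound 2, `COc1cccc(NC2=CC(=O)c3ncncc3C2=O)c1`: 1800 nM

Compound 1 holds the highest of these two numbers. Its nearest neighbour is compound 2, and the gap between the two values lies within the usual scatter of repeated measurements, so the two compounds cannot be told apart on this read-out. Within the data shown here, no pair of measured compounds differs in a single place, so no measured step is available to guide the next change.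

Compound 3, `NS(=O)(=O)c1ccc(NC2=CC(=O)c3ncncc3C2=O)cc1`, has not yet been measured in this assay. Compared with compound 1, it carries sulfamoyl in place of 4-ethylphenyl on an aromatic carbon. The shared core of compound 1 is kept, and the group at the aromatic carbon is exchanged. Among the measured compounds shown here, with only two measured numbers, which lie within the scatter of each other, there is no basis for expecting a change in either direction beyond the scatter, and the step from compound 1 to compound 3 is expected to be a 1.0-fold lower number from compound 1 to compound 3 (0.01 log units; within the scatter). Compound 3 is therefore estimated to give 3000 nM in this assay, with a range from 1000 nM to 10000 nM.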

Compound 3, half-maximal inhibitory concentration: > 10000 nM
Compound 3: no number, only a limit; the forecaster's own chance of this, stated with the estimate: 10%; middle value at least 3.3-fold (0.52 log units) away from the limit.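

In this assay, compound 3 stands at > 10000 nM, which is a limit of the assay and not a number. Putting sulfamoyl in place of 4-ethylphenyl on the aromatic carbon, para to a large group, gives an at least 3.2-fold higher number from compound 1 to compound 3 (0.50 log units; beyond the scatter). Among these compounds, this is the first measured step and it lies beyond the scatter, so this position does not tolerate every group: with the shared core kept, the 4-ethylphenyl of compound 1 cannot be exchanged for sulfamoyl without a loss of inhibition on this read-out.

Among the compounds shown here, the single step removes a six-membered aromatic ring of carbon only and brings in a hydrogen-bond donor and hydrogen-bond acceptors together, so it cannot show whether the loss of the ring or the arrival of sulfamoyl accounts for the change. Also open are how an amine, a carboxylic acid or a plain ethyl group would behave at this position, and how far compound 3 actually lies from compound 1, the size of the step having only a lower bound: the limit of > 10000 nM in this assay, at which 1 of the 3 values shown sits.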